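Swapping a dichlorophenyl for a methoxyphenyl on a shared core

This account rests on a few compounds, and the source may have more. Where it says the series, first, only, none or still open, it means among the compounds named here.

Measured so far:
compound 1, `C=CCn1c(=O)/c(=C\c2cccc(C)c2)[nH]c(=O)/c1=C\c1ccccc1OC`, 19300 nM
compound 2, `COc1ccccc1/C=c1\c(=O)[nH]/c(=C/c2cccc(Cl)c2Cl)c(=O)n1C`, 200 nM
compound 3, `C=CCn1c(=O)/c(=C\c2ccc(F)c(Br)c2)[nH]c(=O)/c1=C\c1ccccc1OC`, "not active" (no number reported)

In a functional assay on HeLa cells (Homo sapiens) for cytotoxicity, read by CCK-8 assay, with a stated time of 72 h (a higher number here means a weaker inhibitor, a lower number a stronger inhibitor), compound 2 gives 200 nM, the lowest of the two numbers available. Its nearest neighbour, compound 1, gives 19300 nM in this assay, a gap far beyond the scatter. In this assay compound 3 is reported as "not active" (no number reported), without a number.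

Compound 4, `COc1ccccc1/C=c1/[nH]c(=O)/c(=C\c2ccccc2OC)n(C)c1=O`, has not been measured. It differs from compound 2 in one place: 2-methoxyphenyl in place of 2,3-dichlorophenyl on a double-bonded chain carbon bound to an aromatic carbon. Both sides of the core of compound 4 now carry a 2-methoxyphenyl. Within the data shown here, no measured pair shows this change, so the direction must be guessed. Compound 2 stands well apart from compound 1 and compound 3, both of which carry other groups on that carbon, so the 2,3-dichlorophenyl may matter; a weaker inhibitor is expected, with the step of a 13-fold higher number from compound 2 to compound 4 (1.10 log units; beyond the scatter) estimated beyond the scatter. Compound 4 is expected to give about 2500 nM, within 400 nM to 20000 nM.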

Compound 4, half-maximal inhibitory concentration: "not active" (no number reported)
No number was reported for compound 4, so the estimate cannot be set against anything.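

Among these compounds, compound 4 is reported without a number, so no step from compound 2 to compound 4 can be read. From the compounds shown here alone, how much the swap of 2,3-dichlorophenyl for 2-methoxyphenyl changes the value of compound 2 stays open. No available evidence bears on this result.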